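From Ethyl to Propyl in a Growth-Inhibition Series

A few compounds are considered here, and "the series" means these few. Any claim that something is new, unique, unknown or untested is made for them only; others in the source may bear on it.

In a functional assay on NCI-H1975 cells (Homo sapiens) for inhibition, with a stated time of 72 h (on this read-out lower numbers stand for stronger inhibition of growth and higher numbers for weaker inhibition of growth), compound 1 (`CN(Cc1ccc(C(=O)NO)cc1)C(=O)c1cc(Cl)c(O)cc1O`) gives 68800 nM and compound 2 (`CCN(Cc1ccc(C(=O)NO)cc1)C(=O)c1cc(Cl)c(O)cc1O`) gives 13200 nM. Compound 2 therefore holds the lower of the two numbers and shows the stronger inhibition of growth of the pair. Compound 3 (`CCCN(Cc1ccc(C(=O)NO)cc1)C(=O)c1cc(Cl)c(O)cc1O`) has not yet been measured. It differs from compound 2 by methyl in place of hydrogen on a saturated chain carbon, two bonds along the chain from an amide-type nitrogen, which is methyl in place of hydrogen on a saturated chain carbon, two bonds along the chain from an amide-type nitrogen. Read one bond further out, this is ethyl to propyl. For the measured compounds named here, only one measured step bears on this change: a 5.2-fold lower number from compound 1 to compound 2 (0.72 log units; beyond the scatter), a modest step in which methyl replaces hydrogen on a saturated chain carbon bound to an amide-type nitrogen. That single step establishes no trend, and the new change lies further along the chain, so a smaller step in the same direction is expected in this assay. The estimated change is a 2.2-fold lower number from compound 2 to compound 3 (0.34 log units; beyond the scatter). For compound 3 the expected value is 6000 nM, within an estimated range of 2000 nM to 16000 nM.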

Compound 3, concentration for 50% growth inhibition: 73600 nM
Compound 3: middle estimate off by 12-fold (1.09 log units), on the low side; measured number outside the range, above it.
By their numbers in this assay, from the lowest: compound 2; then compounds 1 and 3 (each within the scatter of the next).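

The extra methyl on a saturated chain carbon, two bonds along the chain from an amide-type nitrogen, reverses the direction seen so far in this assay: the earlier addition gave a 5.2-fold lower number from compound 1 to compound 2 (0.72 log units; beyond the scatter), whereas this one gives a 5.6-fold higher number from compound 2 to compound 3 (0.75 log units; beyond the scatter). The response at this position is therefore not a steady one as the chain grows, and with compound 2 beyond the scatter of both neighbours, the ethyl group gives the strongest inhibition of growth of the three compounds, while the methyl and propyl groups sit together, with a 1.1-fold higher number from compound 1 to compound 3 (0.03 log units; within the scatter). No measured information accounts for this reversal.

The compounds shown leave open whether a longer chain such as butyl would stay level with compound 3 or move the number further, and whether a branched group such as isopropyl would read like the ethyl group of compound 2 or like the propyl group of compound 3. They also leave open how a hydroxyl or an amine at the end of the chain would read in this assay.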